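Losing the amino link of compound 2

The source may hold more compounds than are shown below. What is called first, only, known or untested is meant among the compounds shown, and "the series" means these compounds.

Values in an ADME assay on the whole organism (serum) with Homo sapiens as the target; on this read-out lower numbers stand for a shorter-lived compound and higher numbers for a longer-lived compound:
- compound 1 `Cc1cn(C2CC(N=[N+]=[N-])C(COC(=O)OCCCCCCCCO)O2)c(=O)[nH]c1=O`: 0.0333 h
- compound 2 `Cc1cn(C2CC(N=[N+]=[N-])C(COC(=O)NCCCC(=O)O)O2)c(=O)[nH]c1=O`: > 48 h (a limit)

Compound 2 reads > 48 h, which is a limit of the assay and not a number. Compound 3 `Cc1cn(C2CC(N=[N+]=[N-])C(COC(=O)CCCC(=O)OC(C)(C)C)O2)c(=O)[nH]c1=O` is still unmeasured. The change is 3-(tert-butoxycarbonyl)propyl in place of (3-carboxypropyl)amino on a carbonyl carbon. Within the data shown here, one measured step bears on this, and it is large. Because an at least 1400-fold higher number from compound 1 to compound 2 (3.15 log units; beyond the scatter) brought in (3-carboxypropyl)amino in place of (8-hydroxyoctyl)oxy, losing that group in compound 3 is expected to give a large fall in this assay. The expected step is an at least 48-fold lower number from compound 2 to compound 3 (1.68 log units; beyond the scatter). The estimate for compound 3 is 1 h, with an expected range of 0.1 h to 10 h.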

Compound 3, half-life: 0.55 h
Compound 3: middle estimate off by 1.8-fold (0.26 log units), on the high side; the measured number falls inside the stated range.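

At this carbonyl carbon, 3-(tert-butoxycarbonyl)propyl does not keep the long life seen with (3-carboxypropyl)amino in this assay (an at least 87-fold lower number from compound 2 to compound 3 (1.94 log units; beyond the scatter)). It also does not fall back to the level of (8-hydroxyoctyl)oxy (a 17-fold higher number from compound 1 to compound 3 (1.22 log units; beyond the scatter)), so this position gives a clear intermediate reading.

The amino link and the tert-butyl ester change together here; a free carboxylic acid on the same carbon chain, without the amino link, would separate them. The reading of compound 2 is a limit and not a number, and the full size of the fall stays open: the limit of > 48 h in this assay, at which 1 of the 3 values shown sits.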